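A ring swap on the amide nitrogen of compound 3

The source may report more compounds than this note shows. Statements on the series, on what has been measured and on what is new or still open speak of the compounds shown alone.

Three close relatives sharing one core have been tested in a functional assay on NCI-H1299 cells (Homo sapiens) for inhibition, read by CCK-8 assay, with a stated time of 72 h, tested at 10 uM; on this read-out lower numbers stand for less inhibition of growth and higher numbers for more inhibition of growth at the one concentration tested. Compound 1 `CN(C)C(=O)c1cc2cnc(Nc3ccc(NC(=O)C4(C(=O)Nc5cccc(F)c5)CC4)cc3)nc2n1C1CCCC1` gives 87%, compound 2 `CN(C)C(=O)c1cc2cnc(Nc3ccc(NC(=O)C4(C(=O)Nc5ccccc5F)CC4)cc3)nc2n1C1CCCC1` gives 89.6%, and compound 3 `CN(C)C(=O)c1cc2cnc(Nc3ccc(NC(=O)C4(C(=O)Nc5ccc(Cl)c(C(F)(F)F)c5)CC4)cc3)nc2n1C1CCCC1` gives 90.4%. Compound 3 therefore stands level with the other two, since these numbers cannot separate any of the three.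

The untested compound 4 `Cc1ccc(NC(=O)C2(C(=O)Nc3ccc(Nc4ncc5cc(C(=O)N(C)C)n(C6CCCC6)c5n4)cc3)CC2)cc1` keeps the shared core and changes one group: 4-methylphenyl in place of 4-chloro-3-(trifluoromethyl)phenyl on an amide-type nitrogen. In words, 4-methylphenyl stands in place of 4-chloro-3-(trifluoromethyl)phenyl on an amide-type nitrogen.

The measured steps that bear on this swap change the ring at that same nitrogen: a number 3.4 percentage points higher from compound 1 to compound 3 (within the scatter), a number 0.8 percentage points higher from compound 2 to compound 3 (within the scatter) and a number 2.6 percentage points higher from compound 1 to compound 2 (within the scatter). All three are small, so exchanging this ring has not yet moved the read-out in this assay beyond the scatter. Among the measured compounds shown here, that evidence covers only three compounds, and none of them carries a 4-methylphenyl group, so the expectation remains an extrapolation. No step beyond the scatter is expected, and the estimated change is a number 3.4 percentage points lower from compound 3 to compound 4 (within the scatter). For compound 4 the estimated value is 87%, with an expected range from 76% to 94%.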

Compound 4, percent growth inhibition at one concentration: 84.5%
Compound 4: the middle estimate sits 2.5 percentage points above what was measured; low and high end bracket the measured number.
By their numbers in this assay, from the lowest: compounds 4, 1, 2 and 3 (each within the scatter of the next).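

Until now every ring on this amide-type nitrogen carried fluorine or chlorine, and compound 4 adds a ring with neither, tested in this assay. Its three steps, a number 5.9 percentage points lower from compound 3 to compound 4 (within the scatter) and a number 5.1 percentage points lower from compound 2 to compound 4 (within the scatter) and a number 2.5 percentage points lower from compound 1 to compound 4 (within the scatter), all stay within the scatter, so among these four compounds this position tolerates a 4-methylphenyl ring as well as the halogen-bearing rings, even though the change from 4-chloro-3-(trifluoromethyl)phenyl takes the group from 11 heavy atoms to 7. Nothing at hand explains why the read-out stays so flat across these rings.

As far as these compounds go, all four groups on this nitrogen are phenyl rings of carbon only, so it remains open whether a ring bearing an amine or a carboxylic acid, a pyridine ring, or a longer alkyl chain in place of the ring would keep the read-out at this level. The numbers also come from a single concentration, so they leave open whether these four compounds would separate from one another at lower concentrations.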